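The compounds below may be only part of what the source reports. "The series", "measured", "known", "first", "only" and "open" are said of these compounds alone.

Working notes on the series. Within the data shown here, compound 2 `Cc1cccc(-c2cn3ccnc3c(-c3ccc4ncn(Cc5ccccc5)c4c3)n2)c1` gives 0.94% in a functional assay on MDA-MB-435 cells (Homo sapiens) for inhibition, read by sulforhodamine B assay, with a stated time of 48 h, tested at 10 uM (on this read-out lower numbers stand for less inhibition and higher numbers for more inhibition at the one concentration tested (going by the name of the read-out)), the lower of the two numbers measured so far. Among the measured compounds shown here, compound 1 `O=Cc1ccc(-c2cn3ccnc3c(-c3ccc4ncn(C5CCCCC5)c4c3)n2)cc1` gives 13% in this assay, a number above that of compound 2 by a margin beyond the usual scatter; the two compounds differ in two places, so no single step between them can be read off.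

Compound 3 `O=Cc1ccc(-c2cn3ccnc3c(-c3ccc4ncn(Cc5ccccc5)c4c3)n2)cc1` is not yet measured. Relative to compound 2 the change is 4-formylphenyl in place of 3-methylphenyl on an aromatic carbon. Compound 3 thus carries the same 4-formylphenyl group as compound 1 but keeps the benzyl of compound 2. A modest rise from compound 2 is expected, of a size a number 6.1 percentage points higher from compound 2 to compound 3 (within the scatter), roughly at the edge of the scatter. Compound 3 is therefore estimated at 7%, with a range from 0% to 18%.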

Compound 3, a percentage reported as inhibition, at one concentration (the size of the read-out at that concentration, not a potency): 13%
Compound 3: middle estimate off by 6 percentage points, on the low side, within the range that was stated.
By their numbers in this assay, from the lowest: compound 2; then compounds 1 and 3 (each within the scatter of the next).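

In this assay, 4-formylphenyl in place of 3-methylphenyl on the aromatic carbon gives a number 12.1 percentage points higher from compound 2 to compound 3 (beyond the scatter), so with the benzyl held fixed, the number responds to the group at this position. Benzyl in place of cyclohexyl on the aromatic nitrogen gives no change at the digits printed from compound 1 to compound 3 (within the scatter), so with 4-formylphenyl held fixed, this pair shows no readable difference between those two nitrogen groups. Nothing at hand bears on why the aromatic-carbon change moves the number.

Among these compounds, the single step replaces both the methyl with a formyl and the 3-substituted phenyl with a 4-substituted one, so it leaves open which of the two accounts for the difference. Also open, on these data alone, is how an amine or a carboxylic acid on that phenyl ring would read out in this assay.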